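Notes on the shared core series, step to compound 3

A few compounds are considered here, and "the series" means these few. Any claim that something is new, unique, unknown or untested is made for them only; others in the source may bear on it.

Compound 2 `COc1ccc(-c2c(C)nc3c(NCc4cccnc4)nc(C)cn23)cc1OC` holds the highest number of the two measured in a physicochemical assay for solubility, in simulated intestinal fluid, measured as thermodynamic solubility, at pH 6.5 (a higher number here means a more soluble compound, a lower number a less soluble compound), at 335 ug/mL. The nearest measured value is that of compound 1 `COc1ccc(-c2c(C)nc3c(NCc4ccc(C(N)=O)cc4)nc(C)cn23)cc1OC`, which in this assay gives 32 ug/mL; the step of a 10-fold higher number from compound 1 to compound 2 (1.02 log units; beyond the scatter) is the only one measured so far in the series. Compound 3 `COc1ccc(-c2c(C)nc3c(NCC4CCOCC4)nc(C)cn23)cc1OC` is not yet measured. It differs from compound 2 in one place: oxan-4-yl in place of pyridin-3-yl on a saturated chain carbon bound to a nitrogen on an aromatic ring. Among the compounds with values here, no measured step covers this change; the single known step concerns a different replacement on the same chain carbon, so it gives direction only loosely. For compound 3 the expected step is a 1.9-fold lower number from compound 2 to compound 3 (0.27 log units; within the scatter), with a wide range since nothing measured bears on it directly. The estimate for compound 3 in this assay is 180 ug/mL, between 50 ug/mL and 500 ug/mL.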

Compound 3, solubility: 7 ug/mL
Estimate against measurement, compound 3: 26-fold (1.41 log units) above, outside the stated range (below it).
By their numbers in this assay, from the lowest: compound 3; then compound 1; then compound 2.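

The group on the saturated chain carbon bound to a nitrogen on an aromatic ring sets a wide spread in this assay, and oxan-4-yl gives the lowest number of the three: the change is a 48-fold lower number from compound 2 to compound 3 (1.68 log units; beyond the scatter) and, against the other aromatic group, a 4.6-fold lower number from compound 1 to compound 3 (0.66 log units; beyond the scatter). Pyridin-3-yl and oxan-4-yl have the same heavy-atom, donor and acceptor counts and the same net charge, so those counts do not track this large step, whereas the ring type and hetero atom do differ. Nothing measured here accounts for the lower number of compound 3.

From the compounds shown here alone, whether the higher number of compound 2 goes with its aromatic ring or with its ring nitrogen stays open. Phenyl and piperidin-4-yl, an amine, on the same chain carbon would separate these two features.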